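Lengthening the amine chain: expected cytotoxicity of compound 3

The source may report more compounds than this note shows. Statements on the series, on what has been measured and on what is new or still open speak of the compounds shown alone.

Compound 1 `CCCCCCCCCCCCCCC(CO)NCCCC` and compound 2 `CCCCCCCCCCCCCCC(CO)NCCCCCC` share a long saturated chain carrying an alcohol and an amine, and differ only by an ethyl in place of hydrogen on a saturated chain carbon, four bonds along the chain from the amine nitrogen. In an ADME assay on cells (Splenocyte, Mus musculus, strain BALB/c) for cytotoxicity, read by MTT assay, tested at 10 ug/mL (a lower number here means a weaker effect, a higher number a stronger effect of the compound at the concentration tested), compound 1 gives 16.4%, and compound 2 gives 14.6%. The step of a number 1.8 percentage points lower from compound 1 to compound 2 (within the scatter) is within the scatter. Among the compounds with values here, on the numbers so far compound 2 sits at the low end of the two, but its gap to compound 1 is within the scatter, so the two are not distinguished.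

Compound 3 `CCCCCCCCCCCCCCC(CO)NCCCCCCCCCC` extends the same chain further: butyl in place of hydrogen on a saturated chain carbon, six bonds along the chain from an amine nitrogen. Within the data shown here, the only measured step bearing on this change is a number 1.8 percentage points lower from compound 1 to compound 2 (within the scatter), which lengthened the same chain and left the read-out essentially unchanged. Nothing in the data points to a step beyond the scatter, so the expected step of a number 1.4 percentage points higher from compound 2 to compound 3 (within the scatter) is small in either direction. Compound 3 is therefore expected to give 16%, within a range from 5% to 32%.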

Compound 3, a percentage reported as activity, at one concentration (the size of the read-out at that concentration, not a potency): 12.6%
For compound 3 the middle estimate is 3.4 percentage points above the measured one; measured number inside the range.
By their numbers in this assay, from the lowest: compounds 3, 2 and 1 (each within the scatter of the next).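

Within the data shown here, putting butyl in place of hydrogen on a saturated chain carbon, six bonds along the chain from an amine nitrogen, gives in this assay a number 2 percentage points lower from compound 2 to compound 3 (within the scatter), so a further extension of the amine chain, larger than the ethyl step among the earlier compounds, still does not separate two compounds. The full change across the series amounts to a number 3.8 percentage points lower from compound 1 to compound 3 (within the scatter), which shows that even the widest gap available here does not distinguish the compounds in this assay. Nothing at hand offers an explanation for why these amine chains of different length read so alike.

The compounds shown leave open whether a much longer chain on the amine, or a carboxylic acid or a phenyl ring at its far end, would move the read-out beyond the scatter. On these data alone, the read-out also comes from a single concentration, so whether these chain lengths would stay alike at higher concentrations remains open.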